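The compounds below may be only part of what the source reports. "The series", "measured", "known", "first", "only" and "open" are said of these compounds alone.

The measured compounds:
Compound 1, `CC(=O)N(CCCN(C)S(=O)(=O)c1ccc(Oc2ccccc2)cc1)Cc1cccc(Cl)c1`, gives 30%
Compound 2, `CC(C)OC(=O)c1ccc(NC(=O)CN(C)C(=O)OCc2ccccc2)cc1-c1cccc(Cl)c1`, gives 24%
Compound 3, `CC(=O)Nc1cccc(S(=O)(=O)N(CC(=O)OC(C)C)c2cccc(Cl)c2)c1`, gives 0%

All three were tested in a functional assay on HEK293 cells for antagonist activity at Voltage-dependent T-type calcium channel subunit alpha-1H (Homo sapiens), read by patch clamp, tested at 1 uM; a lower number here means less inhibition, a higher number more inhibition at the concentration tested (going by the name of the read-out). Compound 3 stands lowest of the three numbers. Its nearest neighbour is compound 2, whose value lies higher by a gap beyond the usual scatter; compound 1 lies further above it, again beyond the scatter. Compound 3 thus shows no measurable inhibition at the tested concentration, while the other two show modest inhibition.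

Compound 4, `CC(C)OC(=O)CN(c1cccc(Cl)c1)S(=O)(=O)c1cccc(NC(=O)CN(C)C(=O)OCc2ccccc2)c1`, has not yet been measured in this assay. It differs from compound 3 in a single place: (benzyloxycarbonyl)(methyl)amino in place of hydrogen on a saturated chain carbon bound to a carbonyl carbon. For the measured compounds named here, no pair of measured compounds differs in exactly this way, so there is no measured step to lean on. Compound 2 carries the same entering group and gives 24%, but the rest of its structure is quite different from that of compound 3, so it offers only a loose hint. Because compound 3 gives 0%, the starting point leaves room only for an upward move. The expected step is a number 10 percentage points higher from compound 3 to compound 4 (within the scatter), upward but small enough to sit within the scatter. Compound 4 is therefore estimated to give 10%, within a range from 0% to 30%.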

Compound 4, a percentage reported as inhibition, at one concentration (the size of the read-out at that concentration, not a potency): 78%
Compound 4: the middle estimate sits 68 percentage points below what was measured; the measured number lies above the stated range.
By their numbers in this assay, from the lowest: compound 3; then compounds 2 and 1 (each within the scatter of the next); then compound 4.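

In this assay, this single change gives a number 78 percentage points higher from compound 3 to compound 4 (beyond the scatter), so the saturated chain carbon bound to a carbonyl carbon is a place where one substitution can turn a compound with no measurable inhibition into a clearly inhibiting one. The earlier compounds shown here could not show this: no pair among them differed in one place, and the (benzyloxycarbonyl)(methyl)amino group appeared only in compound 2, whose structure also differs elsewhere. No measurement available here explains how this group produces the rise.

The compounds shown leave open which part of the entering group matters, and a plain methylamino group, an amine lacking the benzyloxycarbonyl part, would help separate the contribution of that part from the rest of the group. As far as these compounds go, it also remains open whether the rise persists with a longer chain carrying the same group, or with a carboxylic acid in place of the isopropyl ester elsewhere in compound 4.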